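Series notes: the step from compound 3 to compound 4

The source may report more compounds than this note shows. Statements on the series, on what has been measured and on what is new or still open speak of the compounds shown alone.

Values in an in vitro ADME assay on microsomes from liver (Rattus norvegicus) for metabolic stability, tested at 1 uM (a lower number here means that the compound disappears faster, a higher number that the compound lasts longer), for the measured compounds
- Compound 1 `O=C(c1cccnc1)N1CCC(NS(=O)(=O)c2cc(S(=O)(=O)c3ccccc3)ccc2C(F)(F)F)CC1` gives 0.0333 h
- Compound 2 `CN(C)c1ccc(C(=O)N2CCC(NS(=O)(=O)c3cc(S(=O)(=O)c4ccccc4)ccc3C(F)(F)F)CC2)cn1` gives 0.0333 h
- Compound 3 `O=C(O)c1cccc(S(=O)(=O)N2CCC(NS(=O)(=O)c3cc(S(=O)(=O)c4ccccc4)ccc3C(F)(F)F)CC2)c1` gives 0.383 h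

Compound 3 stands highest of the three numbers. Two measured steps change the same nitrogen substituent, and both are large: a 12-fold higher number from compound 1 to compound 3 (1.06 log units; beyond the scatter) and a 12-fold higher number from compound 2 to compound 3 (1.06 log units; beyond the scatter) in the same direction. Compound 4 `CC(C)(O)CCN1CCC(NS(=O)(=O)c2cc(S(=O)(=O)c3ccccc3)ccc2C(F)(F)F)CC1` carries 3-hydroxy-3-methylbutyl in place of (3-carboxyphenyl)sulfonyl on an amine nitrogen in a ring. Among the measured compounds shown here, no measured compound carries that new group, so the size of the step is uncertain. Compound 4 gives up the group found in compound 3 at 0.383 h and a fall in this assay is therefore expected. The estimated change is a 3.2-fold lower number from compound 3 to compound 4 (0.50 log units; beyond the scatter) in this direction. For compound 4 the expected half-life is 0.12 h with an estimated range of 0.033 h to 0.45 h for now.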

Compound 4, half-life: 0.05 h
Compound 4: middle estimate off by 2.4-fold (0.38 log units), on the high side; the measured number falls inside the stated range.
By their numbers in this assay, from the lowest: compounds 1, 2 and 4 (each within the scatter of the next); then compound 3.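

At the amine nitrogen in the ring, 3-hydroxy-3-methylbutyl does not keep the number of (3-carboxyphenyl)sulfonyl in this assay: a 7.7-fold lower number from compound 3 to compound 4 (0.88 log units; beyond the scatter). The chain instead falls within the scatter of both carbonyl-linked groups, with a 1.5-fold higher number from compound 1 to compound 4 (0.18 log units; within the scatter) and a 1.5-fold higher number from compound 2 to compound 4 (0.18 log units; within the scatter), so among these compounds only compound 3 stands apart. Nothing available explains these differences.

The sulfonyl link and the carboxylic acid change together here, so the compounds shown leave open which of them goes with the longer half-life. A plain phenylsulfonyl without the carboxylic acid would separate the two.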